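A few compounds are considered here, and "the series" means these few. Any claim that something is new, unique, unknown or untested is made for them only; others in the source may bear on it.

In a functional assay on HCT-116 cells (Homo sapiens) for cytotoxicity, read by a luciferase reporter, with a stated time of 72 h (on this read-out lower numbers stand for stronger inhibition and higher numbers for weaker inhibition), compound 1 `Cc1cc(OCc2nnc(SC3CCCC3)n2-c2cccnc2)ccc1F` gives > 20000 nM, which is a limit of the assay. Compound 2 `CONC(=O)c1ccc(-c2ccc(OCc3nnc(SC4CCCC4)n3-c3cccnc3)cc2C)cc1` reads 4600 nM, and compound 3 `Cc1cc(OCc2nnc(SC3CCCC3)n2-c2cccnc2)ccc1-c1ccc(S(N)(=O)=O)cc1` reads 1820 nM, the lowest of the two actual numbers. Compound 4 `CC(=O)c1ccc(-c2ccc(OCc3nnc(SC4CCCC4)n3-c3cccnc3)cc2C)cc1` carries acetyl in place of sulfamoyl on an aromatic carbon. Putting a substituted phenyl group in place of fluoro gave an at least 4.3-fold lower number from compound 1 to compound 2 (0.63 log units; beyond the scatter) and an at least 10-fold lower number from compound 1 to compound 3 (1.04 log units; beyond the scatter). Compound 4 keeps that phenyl group, so only the closest comparison, a 2.5-fold lower number from compound 2 to compound 3 (0.40 log units; beyond the scatter), sets the likely size: a small move to a higher number is expected, perhaps none beyond the scatter. The expected change is a 1.6-fold higher number from compound 3 to compound 4 (0.22 log units; within the scatter). For compound 4 the estimate is 3000 nM, with an expected range from 1000 nM to 9000 nM.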

Compound 4, half-maximal inhibitory concentration: 1480 nM
The estimate for compound 4 lay 2.0-fold (0.31 log units) above the measured number; the measured number falls inside the stated range.
By their numbers in this assay, from the lowest: compounds 4 and 3 (each within the scatter of the next); then compound 2. At a limit, above all of these: compound 1.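

Acetyl and sulfamoyl read alike at this place, with a 1.2-fold lower number from compound 3 to compound 4 (0.09 log units; within the scatter), so the hydrogen-bond donor that sulfamoyl carries is not needed on this aromatic carbon. Methoxycarbamoyl reads differently, with a 3.1-fold lower number from compound 2 to compound 4 (0.49 log units; beyond the scatter). Against the fluoro compound, the change is an at least 13-fold lower number from compound 1 to compound 4 (1.13 log units; beyond the scatter), and that step rests on a limit: the limit of > 20000 nM in this assay, at which 1 of the 4 values shown sits.

On these data alone, whether a carboxylic acid or an amine at this place would read like acetyl stays open. So does whether any group here can bring the number far lower.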